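Compound 3 and the step to a phenol

The compounds below may be only part of what the source reports. "The series", "measured", "known", "first", "only" and "open" are said of these compounds alone.

Measured in an ADME assay on HT-29 cells (Homo sapiens) for cytotoxicity, read by MTT assay, with a stated time of 72 h; a lower number here means a stronger inhibitor, a higher number a weaker inhibitor:
- compound 1 `COc1ccc(C2=C(c3cc(OC)c(OC)c(OC)c3)C(=O)CC2O[SiH2]C(C)(C)C)cc1OC`: > 100 ug/mL
- compound 2 `COc1cc(C2=C(c3ccccc3)C(O[SiH2]C(C)(C)C)CC2=O)cc(OC)c1OC`: > 100 ug/mL
- compound 3 `COc1cc(C2=C(c3cc(C)c(OC)c(C)c3)C(O[SiH2]C(C)(C)C)CC2=O)cc(OC)c1OC`: 10 ug/mL

Compound 1 reads > 100 ug/mL, which is a limit of the assay. Compound 2 reads > 100 ug/mL, also a limit. Going by the values given here, compound 3 gives 10 ug/mL, the only actual number of the three.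

Compound 4 `COc1ccc(C2=C(c3cc(OC)c(OC)c(OC)c3)C(=O)CC2O[SiH2]C(C)(C)C)cc1O` differs from it as follows: 3-hydroxy-4-methoxyphenyl in place of 4-methoxy-3,5-dimethylphenyl on a double-bonded ring carbon. In words, 3-hydroxy-4-methoxyphenyl replaces 4-methoxy-3,5-dimethylphenyl on a double-bonded ring carbon.

Two measured steps change the same group: an at least 10-fold lower number from compound 1 to compound 3 (1.00 log units; beyond the scatter) and an at least 10-fold lower number from compound 2 to compound 3 (1.00 log units; beyond the scatter). Both lie beyond the scatter, and both end at the 4-methoxy-3,5-dimethylphenyl group. Losing that group should therefore raise the number, with the estimated step being a 3.0-fold higher number from compound 3 to compound 4 (0.48 log units; beyond the scatter). For compound 4 the expected value is 30 ug/mL, with an estimated range of 4 ug/mL to 200 ug/mL.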

Compound 4, half-maximal inhibitory concentration: 38 ug/mL
Compound 4: the middle estimate sits 1.3-fold (0.10 log units) below what was measured; the range from low to high includes it.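

Hydrogen in place of methyl on an oxygen on an aromatic ring is, on its own, enough to give an at least 2.6-fold lower number from compound 1 to compound 4 (0.42 log units; beyond the scatter) in this assay. Set against phenyl, 3-hydroxy-4-methoxyphenyl gives an at least 2.6-fold lower number from compound 2 to compound 4 (0.42 log units; beyond the scatter), yet in place of 4-methoxy-3,5-dimethylphenyl it gives a 3.8-fold higher number from compound 3 to compound 4 (0.58 log units; beyond the scatter), so this position separates all three groups. The two steps from compounds 1 and 2 are bounds only: the limit of > 100 ug/mL in this assay, at which 2 of the 4 values shown sit.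

The compounds shown leave open whether an amine in place of the hydroxyl on this ring would keep the number of compound 4.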